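Phenylsulfonyl on the piperazine of compound 3

This account rests on a few compounds, and the source may have more. Where it says the series, first, only, none or still open, it means among the compounds named here.

Compound 1 `CCNc1nc(SCc2nc3ccccc3[nH]2)nc(-c2ccccc2)c1C#N` gives 3.96 nM
Compound 2 `N#Cc1c(NC(N)=S)nc(SCc2nc3ccccc3[nH]2)nc1-c1ccccc1` gives 4.8 nM
Compound 3 `N#Cc1c(-c2ccccc2)nc(SCc2nc3ccccc3[nH]2)nc1N1CCNCC1` gives 3.7 nM

All three values come from a functional assay on GOTO cells (Homo sapiens) for cytotoxicity, read by MTT assay, with a stated time of 3 days (a higher number here means a weaker inhibitor, a lower number a stronger inhibitor), and they stay close together. Compound 3 stands within the scatter of the other two, as a 1.1-fold lower number from compound 1 to compound 3 (0.03 log units; within the scatter) and a 1.3-fold lower number from compound 2 to compound 3 (0.11 log units; within the scatter) show. The remaining step, a 1.2-fold higher number from compound 1 to compound 2 (0.08 log units; within the scatter), is also within the scatter. Compound 4 `N#Cc1c(-c2ccccc2)nc(SCc2nc3ccccc3[nH]2)nc1N1CCN(S(=O)(=O)c2ccccc2)CC1` differs from compound 3 by phenylsulfonyl in place of hydrogen on an amine nitrogen in a ring in one place, phenylsulfonyl in place of hydrogen on an amine nitrogen in a ring. Within the data shown here, none of the measured steps puts a group on this nitrogen, so they bear on the change only indirectly. Even so, their small size means that no shift beyond the scatter is expected in this assay for this change, although the uncertainty is wide. The estimate amounts to a 1.1-fold higher number from compound 3 to compound 4 (0.03 log units; within the scatter) as the expected step. Compound 4 is estimated at 4 nM with an expected range from 1.5 nM to 12 nM on this reading.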

Compound 4, half-maximal inhibitory concentration: 5.81 nM
For compound 4 the middle estimate is 1.5-fold (0.16 log units) below the measured one, and the stated range covers the measured number.
By their numbers in this assay, from the lowest: compounds 3, 1, 2 and 4 (each within the scatter of the next).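

In this assay, phenylsulfonyl is the first group shown on this amine nitrogen in the ring, and a 1.6-fold higher number from compound 3 to compound 4 (0.20 log units; within the scatter) is all that the change brings. The position therefore accepts phenylsulfonyl, with its aromatic ring of carbon only, in place of hydrogen, leaving compound 4 within the scatter of compound 3. No measurement shown here accounts for this result. The compounds shown leave open whether a smaller group on this nitrogen, such as methyl or acetyl, would stay within the scatter too. They also leave open whether benzyl, which has no sulfonyl link, or a carboxylic acid would do so.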